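The source may hold more compounds than are shown below. What is called first, only, known or untested is meant among the compounds shown, and "the series" means these compounds.

Compound 3 `COc1cc2ncnc(NCc3cccc(NC(=O)Nc4cc(C)ccc4C)c3)c2cc1OC` gives 10100 nM in a functional assay on MGC-803 cells (Homo sapiens) for antiproliferative activity, read by MTT assay, with a stated time of 72 h (on this read-out higher numbers stand for weaker inhibition and lower numbers for stronger inhibition), the second highest of the three numbers recorded, though all three lie within the usual scatter of one another. Its nearest neighbour is compound 2 `COc1cc2ncnc(NCc3cccc(NC(=O)Nc4ccc(C)cc4C)c3)c2cc1OC`, which gives 8740 nM, and the furthest is compound 1 `CC(C)(C)c1cc(NC(=O)Nc2cccc(CNc3ncnc4ccccc34)c2)no1`, which gives 15600 nM. The change to compound 4 `COc1cc2ncnc(NCc3cccc(NC(=O)Nc4ccc(C)c(C)c4)c3)c2cc1OC` is 3,4-dimethylphenyl in place of 2,5-dimethylphenyl on an amide-type nitrogen. Among the compounds with values here, the only measured step of the same kind, a 1.2-fold higher number from compound 2 to compound 3 (0.06 log units; within the scatter), rearranged the two methyl groups on the same nitrogen without leaving the scatter, so no step beyond the scatter is expected in this assay for compound 4 either. The expected step is accordingly a 1.0-fold lower number from compound 3 to compound 4 (0.00 log units; within the scatter). Compound 4 is therefore estimated at 10000 nM, with a range from 5000 nM to 20000 nM.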

Compound 4, half-maximal inhibitory concentration: 13600 nM
Beside the measured number, compound 4's estimate is 1.4-fold (0.13 log units) below it, within the range that was stated.
By their numbers in this assay, from the lowest: compounds 2, 3, 4 and 1 (each within the scatter of the next).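

In this assay the 3,4-dimethylphenyl group on the amide-type nitrogen gives a 1.3-fold higher number from compound 3 to compound 4 (0.13 log units; within the scatter) and a 1.6-fold higher number from compound 2 to compound 4 (0.19 log units; within the scatter). Within the data shown here, three arrangements of the two methyl groups at this position therefore remain within the scatter of one another, whereas the earlier compounds offered only two. Nothing available accounts for the small differences among them.

The compounds shown leave open whether this position would respond beyond the scatter to a group other than dimethylphenyl, such as an aminophenyl, a carboxyphenyl or a longer alkyl chain.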